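Lengthening the Side Chain on a Trifluoromethyl Analogue

The compounds below may be only part of what the source reports. "The series", "measured", "known", "first", "only" and "open" are said of these compounds alone.

Compound 3 `CCc1cc2ccccc2nc1-c1cc(-c2ccc(C(F)(F)F)cc2)no1` carries an ethyl chain on the shared core and a trifluoromethyl group. In a functional assay on A549 cells (Homo sapiens) for inhibition, read by MTT assay, with a stated time of 24 h (a higher number here means a weaker inhibitor, a lower number a stronger inhibitor), compound 3 reaches only a limit, > 100000 nM. Two related compounds carrying a butyl chain have been measured. Compound 1 `CCCCc1cc2ccccc2nc1-c1cc(-c2ccc(F)cc2)no1` gives 27500 nM in this assay. Compound 2 `CCCCc1cc2ccccc2nc1-c1cc(-c2ccc(C)cc2)no1` gives only a limit in this assay, > 100000 nM. Within the data shown here, the one measured step, an at least 3.6-fold higher number from compound 1 to compound 2 (0.56 log units; beyond the scatter), concerns a group on an aromatic carbon rather than the chain, so no measured step bears directly on the change to compound 4 `CCCCc1cc2ccccc2nc1-c1cc(-c2ccc(C(F)(F)F)cc2)no1`, which differs from compound 3 by ethyl in place of hydrogen on a saturated chain carbon, two bonds along the chain from an aromatic carbon. Of the measured compounds, a pair sit at the limit of > 100000 nM in this assay, at which 2 of the 3 values shown sit, and compound 3 is one of them. With no measured guide for the chain and a starting point already at the edge of what this assay reports, compound 4 is expected to stay close to that edge, with an expected step of a number no higher from compound 3 to compound 4 (the limit leaves the size open). The estimate for compound 4 is 100000 nM, with a range from 30000 nM to 300000 nM.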

Compound 4, half-maximal inhibitory concentration: 9400 nM
Compound 4: the middle estimate sits 11-fold (1.03 log units) above what was measured; the whole stated range lies above it.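

The chain position turns out to matter a great deal: with trifluoromethyl held fixed, going from ethyl to butyl gives an at least 10-fold lower number from compound 3 to compound 4 (1.02 log units; beyond the scatter), and compound 3 stands at a limit of the assay, so this size is only a minimum: the limit of > 100000 nM in this assay, at which 2 of the 4 values shown sit.

With the butyl chain held fixed, the aromatic group matters too, with an at least 10-fold lower number from compound 2 to compound 4 (1.02 log units; beyond the scatter) and a 2.9-fold lower number from compound 1 to compound 4 (0.47 log units; beyond the scatter), which makes compound 4 the strongest inhibitor of the four in this assay. The butyl chain alone is not enough, since compound 2 carries it and gives only a limit, > 100000 nM.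

Going by these compounds, whether a longer chain such as hexyl, or an amine at the end of the chain, would lower the number further stays open. The compounds shown give the chain change with trifluoromethyl alone, so its effect alongside fluoro or methyl is also open.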